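The compounds below may be only part of what the source reports. "The series", "measured", "known", "first", "only" and "open" are said of these compounds alone.

Working notes on the chalcone amide series, cytotoxicity part.

Compound 1 is `CCCCCCCCCCCCNC(=O)c1ccc(/C=C/C(=O)c2ccc(OC)cc2O)cc1`. In an ADME assay on SH-SY5Y cells (Homo sapiens) for cytotoxicity, read by MTT assay, with a stated time of 48 h (a higher number here means a weaker inhibitor, a lower number a stronger inhibitor), compound 1 reaches only the limit of the assay, > 100000 nM. Compound 2 is `CCCNC(=O)c1ccc(/C=C/C(=O)c2ccc(OC)cc2O)cc1`, the hydrogen-for-nonyl analogue. In this assay compound 2 likewise gives only the limit, > 100000 nM. The step that the two limits leave unreadable from compound 1 to compound 2 is therefore unreadable, since both ends are limits; all that is known is the limit of > 100000 nM in this assay, at which 2 of the 2 values shown sit. Going by the values given here, compound 2 thus stands at the limit, with no number of its own, and the one other value shown sits at the same limit.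

The next compound is compound 3, `COc1ccc(C(=O)/C=C/c2ccc(C(=O)Nc3ccccc3OC)cc2)c(O)c1`. It differs from compound 2 by 2-methoxyphenyl in place of propyl on an amide-type nitrogen. Among the compounds with values here, the one measured step, the hydrogen-for-nonyl one, does not bear on an aryl-for-alkyl exchange on the amide nitrogen, and it gave no readable size anyway. Within the data shown here, no measured step supports a direction for the change to compound 3, so the expected step of a number no higher from compound 2 to compound 3 (the limit leaves the size open) is set at none beyond the scatter, with the value most likely again a limit. Compound 3 is estimated at 100000 nM in this assay, within 30000 nM to 300000 nM.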

Compound 3, half-maximal inhibitory concentration: > 100000 nM
Compound 3: only a limit was reported (the forecaster's own chance of this, stated with the estimate: 65%); the middle value lies on the limit itself.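

The step from compound 2 to compound 3 cannot be read, since both ends are limits in this assay and not numbers: the limit of > 100000 nM in this assay, at which 3 of the 3 values shown sit.

With compound 1, compound 2 and compound 3 all at that limit, the compounds shown leave open whether any group on the amide-type nitrogen changes the cytotoxicity read-out at all.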